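Methoxy step in a series read only as limits

The source may hold more compounds than are shown below. What is called first, only, known or untested is meant among the compounds shown, and "the series" means these compounds.

Measured in an ADME assay on Raji cells (Homo sapiens) for cytotoxicity, with a stated time of 72 h (a higher number here means that more compound is needed for the effect, a lower number that less compound is needed), as follows:
- compound 1 `O=C(O)COc1cc(Cl)c(C(=O)Nc2cccc(-c3nc4ccccc4s3)c2)cc1[N+](=O)[O-]` gives > 25000 nM as a limit
- compound 2 `COc1ccc(-c2nc3ccccc3o2)cc1NC(=O)c1cc([N+](=O)[O-])ccc1Cl` gives > 25000 nM as a limit
- compound 3 `O=C(Nc1cccc(-c2nc3ccccc3s2)c1)c1cc([N+](=O)[O-])ccc1Cl` gives > 27000 nM as a limit

Compound 3 stands at a limit and has no number. The other two values shown are limits as well. Compound 4 `COc1ccc(-c2nc3ccccc3s2)cc1NC(=O)c1cc([N+](=O)[O-])ccc1Cl` carries one change against compound 3 (methoxy in place of hydrogen on an aromatic carbon), methoxy in place of hydrogen on an aromatic carbon, ortho to a large group and para to a 1,3-benzothiazol-2-yl group.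

Within the data shown here, the one measured step (a step that the two limits leave unreadable from compound 1 to compound 3) concerns a different group, hydrogen in place of carboxymethoxy. Its size cannot be read, since both of its ends are limits. Among the measured compounds shown here, no measured step covers methoxy in place of hydrogen.

With compound 3 at > 27000 nM as a limit, no step beyond the scatter is expected in this assay, and no direction can be named. The expected step (an at least 1.0-fold lower number from compound 3 to compound 4 (0.01 log units; that floor lies within the scatter)) is estimated to stay within the scatter. Compound 4 is estimated at 26000 nM with an expected range of 10000 nM to 45000 nM in this estimate. A report as a limit alone is the likeliest outcome expected for compound 4.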

Compound 4, half-maximal effective concentration: > 25000 nM
Compound 4 ended at the assay's limit (the forecaster's own chance of this, stated with the estimate: 80%); the middle value is on the limit's open side.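

In this assay compound 4 gives > 25000 nM, a limit and not a number. Its steps from compound 3 and from compound 2 cannot be read: each has a limit at both ends. The compounds shown leave open whether methoxy in place of hydrogen, or 1,3-benzothiazol-2-yl in place of 1,3-benzoxazol-2-yl, changes the concentration needed for the effect.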